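A few compounds are considered here, and "the series" means these few. Any claim that something is new, unique, unknown or untested is made for them only; others in the source may bear on it.

Working notes on the series.

Of the compounds shown here, three have been measured in a functional assay on the whole organism for inhibition, with Rattus norvegicus as the target, read by paw edema, with a stated time of 2 h, at a dose of 50 mg/kg; a higher number here means more inhibition at the dose given (going by the name of the read-out), a lower number less inhibition. Compound 1 `CC(=O)c1c(NNc2ccc(C)cc2)cc(C)oc1=O` gives 53.4%. Compound 2 `Cc1cc2nn(-c3ccccc3)c(C)c2c(=O)o1` gives 55.1%. Compound 3 `Cc1ccc(-n2nc3cc(C)oc(=O)c3c2C)cc1` gives 58.4%, the highest of the three numbers, though its gap to compound 2 and its gap to compound 1 both lie within the scatter, so no order among the three can be read from them. Going by the values given here, the one step between compounds differing in a single place, methyl in place of hydrogen on an aromatic carbon, gave a number 3.3 percentage points higher from compound 2 to compound 3 (within the scatter), within the scatter.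

Compound 4 `Cc1cc2nn(-c3ccc(Cl)cc3)c(C)c2c(=O)o1` is not yet measured. It differs from compound 3 by chloro in place of methyl on an aromatic carbon, at the place described as on an aromatic carbon of a six-membered aromatic ring of carbon only, para to a large group. Among the compounds with values here, no measured step exchanges chloro for methyl, so only the flat step from compound 2 to compound 3 at the same position serves as a guide, and it stayed within the scatter. A change no larger than that is therefore expected here, in no particular direction. Compound 4 is expected to give about 57%, in the range 44% to 70%, an estimated step of a number 1.4 percentage points lower from compound 3 to compound 4 (within the scatter).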

Compound 4, a percentage reported as inhibition, in the whole organism at one dose (the size of the read-out at that dose, not a potency): 59.6%
Compound 4: the middle estimate sits 2.6 percentage points below what was measured; measured number inside the range.
By their numbers in this assay, from the lowest: compounds 1, 2, 3 and 4 (each within the scatter of the next).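

At this position, on an aromatic carbon of a six-membered aromatic ring of carbon only, para to a large group, chloro can now be set against both methyl and hydrogen. In this assay chloro in place of methyl gives a number 1.2 percentage points higher from compound 3 to compound 4 (within the scatter) and chloro in place of hydrogen gives a number 4.5 percentage points higher from compound 2 to compound 4 (within the scatter) so neither step separates the groups, and the flat result seen earlier with methyl alone now extends to a group with a different atom. No supporting measurement is available to explain this flat result.

From the compounds shown here alone, whether an amine, a carboxylic acid or a longer chain at this position would produce a step beyond the scatter remains open. Also open, going by these compounds, is whether hydrogen, methyl and chloro would remain this close at another dose or time.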